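Moving the methoxy group on the aryl piperazine of compound 3

The compounds below may be only part of what the source reports. "The series", "measured", "known", "first", "only" and "open" are said of these compounds alone.

Measured so far:
Compound 1, `COc1cccc(N2CCN(c3ccc(C(=O)/C=C/c4ccccc4)cc3)CC2)c1`, gives 16%.
Compound 2, `Cc1ccc(N2CCN(c3ccc(C(=O)/C=C/c4ccc(Cl)cc4)cc3)CC2)c(C)c1`, gives 25.7%.
Compound 3, `COc1ccc(N2CCN(c3ccc(C(=O)/C=C/c4ccc(Cl)cc4)cc3)CC2)cc1`, gives 55.1%.

These three values come from a functional assay on the whole organism (strain Kunming) for inhibition, with Mus musculus as the target, with a stated time of 1 h, at a dose of 40 mg/kg by the oral route; on this read-out lower numbers stand for less inhibition and higher numbers for more inhibition at the one dose given (going by the name of the read-out). Compound 3 stands highest of the three, and both gaps separating it from compound 2 and from compound 1 lie beyond the scatter. Among the compounds with values here, the one single-point step on record, a number 29.4 percentage points higher from compound 2 to compound 3 (beyond the scatter), is the only change that was measured directly.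

Compound 4, `COc1cccc(N2CCN(c3ccc(C(=O)/C=C/c4ccc(Cl)cc4)cc3)CC2)c1`, has not yet been measured in this assay. Relative to compound 3 the change is 3-methoxyphenyl in place of 4-methoxyphenyl on an amine nitrogen in a ring. Within the data shown here, no measured step matches this change. Compound 1, which also carries a 3-methoxyphenyl group, gives 16%, but it differs from compound 3 in a second place as well, so its low value can only hint at the direction. Compound 4 is therefore expected to fall below compound 3 by a number 20.1 percentage points lower from compound 3 to compound 4 (beyond the scatter), with wide uncertainty. The estimate for compound 4 is 35%, within a range from 15% to 55%.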

Compound 4, a percentage reported as inhibition, in the whole organism at one dose (the size of the read-out at that dose, not a potency): 2.28%
For compound 4 the middle estimate is 32.7 percentage points above the measured one; the whole stated range lies above it.
By their numbers in this assay, from the lowest: compound 4; then compounds 1 and 2 (each within the scatter of the next); then compound 3.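

In this assay, the same atoms joined differently give a number 52.8 percentage points lower from compound 3 to compound 4 (beyond the scatter), so 3-methoxyphenyl and 4-methoxyphenyl are far from interchangeable on this amine nitrogen in a ring. The 3-methoxyphenyl group also falls short of 2,4-dimethylphenyl, with a number 23.4 percentage points lower from compound 2 to compound 4 (beyond the scatter), which shows that carrying a methoxy group does not by itself secure a high reading. Chloro in place of hydrogen on an aromatic carbon brings no gain with 3-methoxyphenyl in place, giving a number 13.7 percentage points lower from compound 1 to compound 4 (beyond the scatter), and no measurement at hand accounts for any of these differences.

The compounds shown leave open how an ethoxy group, a hydroxyl group or a fluorine atom in place of the methoxy group would read. Also open, from the compounds shown here alone, is whether these steps would hold with a bromo group in place of the chloro group.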